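A few compounds are considered here, and "the series" means these few. Any claim that something is new, unique, unknown or untested is made for them only; others in the source may bear on it.

Values so far in a functional assay on L1210 cells (Mus musculus) for antiproliferative activity, read by cell counting, with a stated time of 2 days; a higher number here means a weaker inhibitor, a lower number a stronger inhibitor
Compound 1 `COc1cccc(Nc2nc(N)c(C(=O)c3ccccc3)s2)c1`: 8200 nM
Compound 2 `COc1ccc(Nc2nc(N)c(C(=O)c3ccc(Cl)cc3)s2)cc1`: 84 nM
Compound 3 `COc1ccc(Nc2nc(N)c(C(=O)c3cc(OC)c(OC)c(OC)c3)s2)cc1`: 1500 nM

Compound 2 at 84 nM holds the lowest number of the three. Compound 3 at 1500 nM is the nearest and compound 1 at 8200 nM the furthest, both gaps lying beyond the scatter.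

Compound 4 `COc1ccc(Nc2nc(N)c(C(=O)c3ccccc3OC)s2)cc1` departs from compound 2 in one place, with 2-methoxyphenyl in place of 4-chlorophenyl on a carbonyl carbon as the whole of the change. Among the compounds with values here, no measured step covers this change, so the expectation rests on thin ground. Compound 2 alone carries 4-chlorophenyl, and neither compound 1 nor compound 3 comes near its number. A move to a higher number is therefore expected in this assay beyond the scatter, with the size estimated as an 18-fold higher number from compound 2 to compound 4 (1.25 log units; beyond the scatter) on present data. The estimated value for compound 4 is 1500 nM with an expected range of 300 nM to 8000 nM at this stage.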

Compound 4, half-maximal inhibitory concentration: 31 nM
The estimate for compound 4 lay 48-fold (1.68 log units) above the measured number, and the stated range ends above it.
By their numbers in this assay, from the lowest: compound 4; then compound 2; then compound 3; then compound 1.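

On a carbonyl carbon, exchanging 4-chlorophenyl for 2-methoxyphenyl gives, in this assay, a 2.7-fold lower number from compound 2 to compound 4 (0.43 log units; beyond the scatter) and this step lies beyond the scatter. A low number at this position therefore does not depend on 4-chlorophenyl: a group with no chlorine and with a hydrogen-bond acceptor, which 4-chlorophenyl lacks, also reaches one. No measurement at hand accounts for the step.

Within the data shown here, it remains open whether the methoxy group, its place on the ring or the loss of chlorine governs the number, as no single compound here separates these changes. On these data alone, the readings of 2-chlorophenyl, 4-methoxyphenyl, 2-ethoxyphenyl and 2-aminophenyl on the core of compound 4 also remain open.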